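This account rests on a few compounds, and the source may have more. Where it says the series, first, only, none or still open, it means among the compounds named here.

Series notes. Compound 1 `O=C(CSc1nnc(-c2ccncc2)o1)N/N=C/c1ccc(O)cc1` carries an aromatic ring on a carbon with a double bond to nitrogen; in a functional assay on SW 1116 cells (Homo sapiens) for cytotoxicity, read by MTT assay, with a stated time of 48 h (a higher number here means a weaker inhibitor, a lower number a stronger inhibitor), compound 1 gives 12200 nM. Compound 2 `O=C(CSc1nnc(-c2ccncc2)o1)N/N=C/c1cc(Br)ccc1O` has 5-bromo-2-hydroxyphenyl at that carbon, and in this assay compound 2 gives 8150 nM, a step of a 1.5-fold lower number from compound 1 to compound 2 (0.18 log units; within the scatter). Among the measured compounds shown here, compound 2 thus shows the lowest of the two numbers so far, though its gap to compound 1 stays within the scatter, so the two are not ranked.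

Compound 3 `O=C(CSc1nnc(-c2ccncc2)o1)N/N=C/c1cc(Cl)cc(Cl)c1O` is not yet measured. Its change from compound 2 is 3,5-dichloro-2-hydroxyphenyl in place of 5-bromo-2-hydroxyphenyl on a carbon with a double bond to nitrogen. For the measured compounds named here, the only measured step that bears on a change of the ring at this carbon is a 1.5-fold lower number from compound 1 to compound 2 (0.18 log units; within the scatter), which lay within the scatter; the move to 3,5-dichloro-2-hydroxyphenyl gives no ground to expect a step beyond the scatter in this assay. Compound 3 is therefore expected at 6500 nM, between 2500 nM and 17000 nM, the expected step being a 1.3-fold lower number from compound 2 to compound 3 (0.10 log units; within the scatter).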

Compound 3, half-maximal inhibitory concentration: 5030 nM
Compound 3: middle estimate off by 1.3-fold (0.11 log units), on the high side; the measured number falls inside the stated range.
By their numbers in this assay, from the lowest: compounds 3, 2 and 1 (each within the scatter of the next, the first and the last beyond it).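

In this assay, 3,5-dichloro-2-hydroxyphenyl in place of 5-bromo-2-hydroxyphenyl gives a 1.6-fold lower number from compound 2 to compound 3 (0.21 log units; within the scatter) and so leaves compound 2 and compound 3 unranked. Among the compounds shown here, the same ring compared with 4-hydroxyphenyl gives a 2.4-fold lower number from compound 1 to compound 3 (0.38 log units; beyond the scatter) and is the first step beyond the scatter, showing that a change of ring on this carbon can shift the read-out, if only modestly. No measurement at hand accounts for that step.

The step from compound 1 to compound 3 changes the halogens and the place of the hydroxy group together, and the compounds shown do not separate the two. Also open, going by these compounds, is how the read-out responds to an amine or a carboxylic acid on this ring, or to a ring without a hydroxy group.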